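This account rests on a few compounds, and the source may have more. Where it says the series, first, only, none or still open, it means among the compounds named here.

Working notes on the cytotoxicity series

Three members of the series have been measured. Compound 1 `COc1cc(-c2nnc(SCc3ccc(C)cc3)o2)ccc1O` gives 549000 nM in an ADME assay on cells (Mus musculus, strain BALB/c) for cytotoxicity, read by MTT assay, with a stated time of 24 h; on this read-out higher numbers stand for lower toxicity in this test and lower numbers for higher toxicity in this test. Compound 2 `COc1cc(-c2nnc(SCc3cccc([N+](=O)[O-])c3)o2)ccc1O` gives 392000 nM in this assay, and compound 3 `COc1cc(-c2nnc(SCc3cccc(Cl)c3)o2)ccc1O` gives 470000 nM in this assay. Compound 3 holds the second highest of the three numbers, and both neighbouring steps are small: a 1.2-fold lower number from compound 1 to compound 3 (0.07 log units; within the scatter) and a 1.2-fold higher number from compound 2 to compound 3 (0.08 log units; within the scatter), each within the scatter, so the three measured compounds cannot be separated on this read-out.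

Compound 4 `COc1cc(-c2nnc(SCc3cccc(Cl)c3)o2)ccc1OCc1cccc(Cl)c1` has not yet been measured. The change from compound 3 to compound 4 is 3-chlorobenzyl in place of hydrogen on an oxygen on an aromatic ring, that is, hydroxy to (3-chlorobenzyl)oxy. Among the compounds with values here, none of the measured steps touches this oxygen; they vary only the group on the saturated chain carbon bound to sulfur, and both stayed within the scatter. Within the data shown here, no measured step therefore bears directly on this change, and the expectation rests on the narrow spread of the three measured numbers. The expected outcome is a step of a 1.3-fold lower number from compound 3 to compound 4 (0.13 log units; within the scatter) in this assay, not clearly beyond the scatter. Compound 4 is estimated at 350000 nM, with a range from 150000 nM to 700000 nM.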

Compound 4, half-maximal cytotoxic concentration: 178000 nM
The estimate for compound 4 lay 2.0-fold (0.29 log units) above the measured number, and the stated range covers the measured number.
By their numbers in this assay, from the lowest: compound 4; then compounds 2, 3 and 1 (each within the scatter of the next).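

Within the data shown here, the oxygen on the aromatic ring responds where the group on the saturated chain carbon bound to sulfur did not: in this assay the change from hydroxy to (3-chlorobenzyl)oxy gives a 2.6-fold lower number from compound 3 to compound 4 (0.42 log units; beyond the scatter) and is the first step beyond the scatter. The step is modest and points towards higher toxicity in this test. It both removes the hydrogen from this oxygen and adds 8 heavy atoms with one six-membered aromatic ring, and this single step does not separate those two parts of the change. Nothing available gives a reason for the step.

Open, on these data alone, is whether a methyl group, a longer alkyl chain or a chain ending in an amine on this oxygen would give a step of similar size. Also open, as far as these compounds go, is whether the chlorine of the 3-chlorobenzyl group matters, which an unsubstituted benzyl group on this oxygen would address.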